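Stability Outlook for a Dioxopiperidinyl Analogue

The compounds below may be only part of what the source reports. "The series", "measured", "known", "first", "only" and "open" are said of these compounds alone.

Compound 1 `O=C1c2cccc(OCCOCCOCCOCc3ccccc3)c2C(=O)N1C1CCCCC1`: 90%
Compound 2 `O=C1NCCCC1N1C(=O)c2cccc(OCCOCCOCCOCc3ccccc3)c2C1=O`: 99%

In a physicochemical assay, read by HPLC, with a stated time of 24 h, at pH 7.4 (a higher number here means that more of the compound is left, a lower number that less of the compound is left), compound 2 gives 99%. Compound 1 gives 90%, and the step of a number 9 percentage points higher from compound 1 to compound 2 (within the scatter) lies within the scatter, so the two compounds cannot be ranked against each other. Compound 3 `O=C1CCC(N2C(=O)c3cccc(OCCOCCOCCOCc4ccccc4)c3C2=O)C(=O)N1` differs from compound 2 as follows: 2,6-dioxopiperidin-3-yl in place of 2-oxopiperidin-3-yl on an amide-type nitrogen in a ring. Among the measured compounds shown here, the single measured step concerns a different change and was itself within the scatter, so nothing measured bears directly on this new change. Compound 3 is therefore expected to show a number 11 percentage points lower from compound 2 to compound 3 (beyond the scatter), no step beyond the scatter, with a wide range to reflect the lack of data. Compound 3 is estimated at 88%, between 65% and 100%.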

Compound 3, percent of the compound remaining: 46%
Compound 3: middle estimate off by 42 percentage points, on the high side; measured number outside the range, below it.
By their numbers in this assay, from the lowest: compound 3; then compounds 1 and 2 (each within the scatter of the next).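

Compared with 2-oxopiperidin-3-yl, 2,6-dioxopiperidin-3-yl on the amide-type nitrogen gives a number 53 percentage points lower from compound 2 to compound 3 (beyond the scatter) in this assay and so shows that this position can strongly affect how much compound is left. With cyclohexyl as the starting point, the same group gives a number 44 percentage points lower from compound 1 to compound 3 (beyond the scatter) in this assay and so the drop appears against both other groups shown. The data shown offer no explanation for this drop.

On these data alone, it remains open whether the drop would persist with a methyl group in place of the amide hydrogen of 2,6-dioxopiperidin-3-yl, or with an amine added to the shared core.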